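A few compounds are considered here, and "the series" means these few. Any claim that something is new, unique, unknown or untested is made for them only; others in the source may bear on it.

Measured so far in a functional assay on HepG2 cells (Homo sapiens) for antiproliferative activity, read by MTT assay, with a stated time of 48 h; on this read-out higher numbers stand for weaker inhibition and lower numbers for stronger inhibition:

Compound 1, `CC(=O)N1N=C(c2ccc3ccccc3c2)OC1c1ccccc1`: 2.11 ug/mL
Compound 2, `CC(=O)N1N=C(c2ccc3ccccc3c2)OC1c1ccc(Cl)cc1`: 1.88 ug/mL

Compound 1 stands with the highest of the two numbers in this assay, but its nearest neighbour, compound 2, sits within the scatter of it: the step is a 1.1-fold lower number from compound 1 to compound 2 (0.05 log units; within the scatter), so the two results cannot be told apart.

The compound now in question is compound 3, `CC(=O)N1N=C(c2ccc3ccccc3c2)OC1c1ccc(F)cc1`. It differs from compound 1 in one place only: fluoro in place of hydrogen on an aromatic carbon. Among the measured compounds shown here, the only measured step that bears on this change is the one from compound 1 to compound 2, where chloro in place of hydrogen on an aromatic carbon gave a 1.1-fold lower number from compound 1 to compound 2 (0.05 log units; within the scatter), a step within the scatter. Fluoro and chloro are both single halogen atoms entering at the same place on the shared core, so the one available comparison suggests that compound 3 should give a number close to that of compound 1, with no step beyond the scatter in either direction.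

For compound 3 the expected value in this assay is therefore 2 ug/mL, with a range from 1 ug/mL to 4 ug/mL, which corresponds to an estimated step of a 1.1-fold lower number from compound 1 to compound 3 (0.02 log units; within the scatter).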

Compound 3, half-maximal inhibitory concentration: 1.82 ug/mL
Compound 3: middle estimate off by 1.1-fold (0.04 log units), on the high side; the range from low to high includes it.
By their numbers in this assay, from the lowest: compounds 3, 2 and 1 (each within the scatter of the next).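

In this assay, fluoro on this aromatic carbon, para to a large group, gives a 1.2-fold lower number from compound 1 to compound 3 (0.06 log units; within the scatter) and so joins chloro as a second halogen whose result cannot be told apart from that of the plain phenyl compound. Among the compounds shown here, the direct exchange of one halogen for the other adds a comparison the earlier compounds could not offer, giving a 1.0-fold lower number from compound 2 to compound 3 (0.01 log units; within the scatter) and showing that, at this position, fluoro in place of chloro also makes no readable difference, so hydrogen, fluoro and chloro here form a set of three indistinguishable results. No outside information is available to explain why these three results sit so close together.

The compounds shown carry only hydrogen or a single halogen at this place, so it remains open whether an amine, a carboxylic acid, a methoxy group or a longer chain there would give a step beyond the scatter. From the compounds shown here alone, it is also open whether changes elsewhere on the shared core would move the number any more than these have.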